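Swapping the urea end of compound 1 for a carbamate

The source may report more compounds than this note shows. Statements on the series, on what has been measured and on what is new or still open speak of the compounds shown alone.

Compound 1 `CC(C)NC(=O)N1CCC(CN(C2Cc3cc(C#N)ccc3N(Cc3cncn3C)C2)S(=O)(=O)c2ccccn2)CC1` is measured in an ADME assay on Caco-2 cells (Homo sapiens) for permeability, in the apical to basolateral direction (a lower number here means that the compound crosses the layer more slowly, a higher number that the compound crosses the layer faster), and gives 0.6 10^-6 cm/s. Compound 2 `Cn1cncc1CN1CC(N(CC2CCN(C(=O)Nc3ccc(Br)cc3)CC2)S(=O)(=O)c2ccccn2)Cc2cc(C#N)ccc21` gives 0.6 10^-6 cm/s, and compound 3 `CCNC(=O)N1CCC(CN(C2Cc3cc(C#N)ccc3N(Cc3cncn3C)C2)S(=O)(=O)c2ccccn2)CC1` gives 0.6 10^-6 cm/s, so compound 1 sits level with both. Compound 4 `Cn1cncc1CN1CC(N(CC2CCN(C(=O)OCc3ccccc3)CC2)S(=O)(=O)c2ccccn2)Cc2cc(C#N)ccc21` differs from compound 1 at the carbonyl carbon: benzyloxy in place of isopropylamino on a carbonyl carbon. Among the measured compounds shown here, two measured steps touch the same end of the molecule: no change at the digits printed from compound 1 to compound 2 (within the scatter) and no change at the digits printed from compound 1 to compound 3 (within the scatter). Neither moved the value, so a change at this position is expected to leave the read-out where compound 1 stands or shift it only slightly. Compound 4 is therefore estimated at 0.8 10^-6 cm/s, between 0.3 10^-6 cm/s and 2.5 10^-6 cm/s, an expected step of a 1.3-fold higher number from compound 1 to compound 4 (0.12 log units; within the scatter).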

Compound 4, apparent permeability: 1 10^-6 cm/s
Compound 4: middle estimate off by 1.3-fold (0.10 log units), on the low side; measured number inside the range.
By their numbers in this assay, from the lowest: compounds 1, 2, 3 and 4 (each within the scatter of the next).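

Every earlier compound carries an amino group on this carbonyl carbon, so only ureas had been seen at this end of the molecule. In this assay, benzyloxy, which has no hydrogen-bond donor, stays within the scatter of isopropylamino (a 1.7-fold higher number from compound 1 to compound 4 (0.22 log units; within the scatter)), ethylamino (a 1.7-fold higher number from compound 3 to compound 4 (0.22 log units; within the scatter)) and (4-bromophenyl)amino (a 1.7-fold higher number from compound 2 to compound 4 (0.22 log units; within the scatter)). No measurement here offers an explanation for this result.

Because benzyloxy differs from the earlier groups in both its oxygen and its place for the aromatic ring, the two changes cannot be told apart. Benzylamino or methoxy on this carbonyl carbon would be needed to separate them.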